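The compounds below may be only part of what the source reports. "The series", "measured", "known", "first", "only" and "open" are said of these compounds alone.

In a functional assay on PC-3 cells (Homo sapiens) for cytotoxicity, read by WST assay, with a stated time of 48 h (on this read-out higher numbers stand for weaker inhibition and lower numbers for stronger inhibition), compound 1 `N#C/C(=C\c1c[nH]c2cc(F)ccc12)C(=O)c1c[nH]c2ccccc12` gives > 50000 nM, which is a limit of the assay and not a number. Among the compounds with values here, compound 2 `COc1ccc2c(C(=O)/C(C#N)=C/c3c[nH]c4cc(F)ccc34)c[nH]c2c1` gives 22500 nM, the only true number so far. Compound 3 `COc1ccc2c(C(=O)/C(C#N)=C/c3c[nH]c4ccccc34)c[nH]c2c1` has hydrogen in place of fluoro on an aromatic carbon. Within the data shown here, the one measured step, an at least 2.2-fold lower number from compound 1 to compound 2 (0.34 log units; beyond the scatter), is a methoxy change and involves no fluoro, so it bears only indirectly. Its size rests on (the limit of > 50000 nM in this assay, at which 1 of the 2 values shown sits). The expected result in this assay is a 1.1-fold higher number from compound 2 to compound 3 (0.05 log units; within the scatter), with no shift beyond the scatter. Compound 3 is expected at 25000 nM, with an estimated range of 10000 nM to 50000 nM.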

Compound 3, half-maximal inhibitory concentration: 12000 nM
Beside the measured number, compound 3's estimate is 2.1-fold (0.32 log units) above it; low and high end bracket the measured number.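

First reading at this position: in this assay, a 1.9-fold lower number from compound 2 to compound 3 (0.27 log units; within the scatter), so fluoro and hydrogen on this aromatic carbon, meta to a fused ring and para to a fused ring, are not told apart with the methoxy group present. The fluoro is therefore not required for the activity of compound 3 on this read-out. No available evidence bears on the reason for this result. Open, as far as these compounds go, is whether an amine or a carboxylic acid on this aromatic carbon would give a step beyond the scatter. Also open, from the compounds shown here alone, is whether fluoro and hydrogen remain indistinguishable without the methoxy group.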